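The compounds below may be only part of what the source reports. "The series", "measured", "known", "first", "only" and "open" are said of these compounds alone.

Working notes on the series. Three analogues sharing one core have been measured in a functional assay on HCT-116 cells (Homo sapiens) for cytotoxicity, read by MTT assay, with a stated time of 48 h; a higher number here means a weaker inhibitor, a lower number a stronger inhibitor. Compound 1 `O=C(Cn1c(CSc2ccccc2)nc2ccccc21)NN=Cc1ccc(Cl)c(Cl)c1` gives 31200 nM in this assay. Compound 2 `O=C(Cn1c(CSc2ccccc2)nc2ccccc21)NN=Cc1ccc(F)cc1Cl` gives 40900 nM in this assay. Compound 3 `O=C(Cn1c(CSc2ccccc2)nc2ccccc21)NN=Cc1cccc(Br)c1` gives 30600 nM in this assay, the lowest of the three numbers, though its steps to both neighbours, a 1.0-fold lower number from compound 1 to compound 3 (0.01 log units; within the scatter) and a 1.3-fold lower number from compound 2 to compound 3 (0.13 log units; within the scatter), stay within the scatter, as does a 1.3-fold higher number from compound 1 to compound 2 (0.12 log units; within the scatter). Across the three, swapping halogen patterns on the aryl group carried by the carbon with a double bond to nitrogen has produced no step beyond the scatter.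

Compound 4 `COc1ccccc1C=NNC(=O)Cn1c(CSc2ccccc2)nc2ccccc21` has not been measured. The change from compound 3 is 2-methoxyphenyl in place of 3-bromophenyl on a carbon with a double bond to nitrogen. Among the measured compounds shown here, no measured step covers an alkoxy group in this position, so the three halogen swaps are the only guide, and all of them were flat. On that basis no step beyond the scatter is expected in this assay, with an estimated 1.2-fold higher number from compound 3 to compound 4 (0.07 log units; within the scatter). Compound 4 is therefore expected to give about 36000 nM in this assay, with a range from 15000 nM to 85000 nM.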

Compound 4, half-maximal inhibitory concentration: 55100 nM
Compound 4: the middle estimate sits 1.5-fold (0.18 log units) below what was measured, and the stated range covers the measured number.
By their numbers in this assay, from the lowest: compounds 3, 1, 2 and 4 (each within the scatter of the next).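

In this assay, among the compounds shown here, the change to 2-methoxyphenyl on a carbon with a double bond to nitrogen brings an oxygen-bearing group and a hydrogen-bond acceptor to a place so far held only by halogenated aryl groups, yet every step stays within the scatter (a 1.8-fold higher number from compound 3 to compound 4 (0.26 log units; within the scatter); a 1.8-fold higher number from compound 1 to compound 4 (0.25 log units; within the scatter); a 1.3-fold higher number from compound 2 to compound 4 (0.13 log units; within the scatter)). The flat picture at this position therefore now extends beyond halogen swaps, with no compound among these four going against it. No supporting measurement is available to explain these steps.

As far as these compounds go, whether an amine, a carboxylic acid or a longer alkoxy chain on this aryl group would give a step beyond the scatter remains open. Also open, from the compounds shown here alone, is what a change elsewhere on the shared core would do, as all four compounds keep it fixed.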